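Nitro for Cyano on a Phthalimide-Thiazole Pair

This account rests on a few compounds, and the source may have more. Where it says the series, first, only, none or still open, it means among the compounds named here.

Compound 1 `O=C1c2ccccc2C(=O)N1c1nc(-c2ccc([N+](=O)[O-])cc2)cs1`: 41800 nM
Compound 2 `N#Cc1ccc(-c2csc(N3C(=O)c4ccc(F)cc4C3=O)n2)cc1`: 43100 nM

Of the compounds shown here, two have been measured in a functional assay on PC-3 cells (Homo sapiens) for antiproliferative activity, read by MTT assay, with a stated time of 48 h; on this read-out lower numbers stand for stronger inhibition and higher numbers for weaker inhibition. Compound 1 `O=C1c2ccccc2C(=O)N1c1nc(-c2ccc([N+](=O)[O-])cc2)cs1` gives 41800 nM in this assay. Compound 2 `N#Cc1ccc(-c2csc(N3C(=O)c4ccc(F)cc4C3=O)n2)cc1` gives 43100 nM in this assay, the higher of the two numbers, though its gap to compound 1 lies within the scatter of repeated measurements, so the two stand level.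

Compound 3 `O=C1c2ccc(F)cc2C(=O)N1c1nc(-c2ccc([N+](=O)[O-])cc2)cs1` is not yet measured. It differs from compound 2 in one place: nitro in place of cyano on an aromatic carbon. Going by the values given here, no step between measured compounds tells how this particular change plays out. Among the compounds with values here, the only guide is that the two measured compounds, which both carry the shared core with a para substituent on the phenyl ring, stand level in this assay. An exchange of one such group for another is therefore expected to give no step beyond the scatter, in either direction.

Compound 3 is estimated at 42000 nM in this assay, with a range of 20000 nM to 90000 nM. This estimate means a step of a 1.0-fold lower number from compound 2 to compound 3 (0.01 log units; within the scatter), which is expected to be within the scatter.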

Compound 3, half-maximal inhibitory concentration: 39900 nM
Compound 3: middle estimate off by 1.1-fold (0.02 log units), on the high side; the measured number falls inside the stated range.
By their numbers in this assay, from the lowest: compounds 3, 1 and 2 (each within the scatter of the next).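

In this assay, the exchange of cyano for nitro on an aromatic carbon, para to a large group, now has a step of its own, a 1.1-fold lower number from compound 2 to compound 3 (0.03 log units; within the scatter), whereas compounds 1 and 2 differ in more than one place and could not isolate it. The second new step isolates another change, fluoro in place of hydrogen on an aromatic carbon of the shared core, and gives a 1.0-fold lower number from compound 1 to compound 3 (0.02 log units; within the scatter), so with the nitro group held in place, this change too stays within the scatter, and neither single exchange separates the compounds in this read-out. No further measurement accompanies these steps, and nothing at hand bears on what lies behind them.

The compounds shown leave open whether an amine or a carboxylic acid on that aromatic carbon, in place of cyano or nitro, would give a step beyond the scatter. They also leave open whether chloro or methoxy in place of the fluoro group would move the number in this assay beyond the scatter.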